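Series notes: aryl swap on the ester chain of compound 1

This account rests on a few compounds, and the source may have more. Where it says the series, first, only, none or still open, it means among the compounds named here.

Two compounds in this set carry a measurement. In a functional assay on CCRF-CEM cells (Homo sapiens) for antiproliferative activity, read by MTT assay, with a stated time of 72 h, tested at 100 uM (a higher number here means a weaker effect of the compound at the concentration tested, a lower number a stronger effect), compound 1, `COC(C(=O)OC(C)Cn1cnc2c1c(=O)n(C)c(=O)n2C)c1ccc(C(C)(C)C)cc1`, gives 28.6%, the highest of the two numbers. Compound 2, `CC(Cn1cnc2c1c(=O)n(C)c(=O)n2C)OCc1cn(CCCn2nc3c(Br)c(Br)c(Br)c(Br)c3n2)nn1`, gives 0% in this assay, a number lower than compound 1 by a margin beyond the scatter. Compound 3, `COC(C(=O)OC(C)Cn1cnc2c1c(=O)n(C)c(=O)n2C)c1ccc2ccccc2c1`, is not yet measured; it differs from compound 1 by naphthalen-2-yl in place of 4-(tert-butyl)phenyl on a saturated chain carbon bound to a carbonyl carbon and an oxygen on a saturated carbon. Among the compounds with values here, no measured pair shows this change, so the step of a number 1.4 percentage points higher from compound 1 to compound 3 (within the scatter) is expected to stay within the scatter, without a clear direction. Compound 3 is estimated at 30%, with a range from 10% to 55%.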

Compound 3, a percentage reported as activity, at one concentration (the size of the read-out at that concentration, not a potency): 27.6%
Compound 3: middle estimate off by 2.4 percentage points, on the high side, and the stated range covers the measured number.
By their numbers in this assay, from the lowest: compound 2; then compounds 3 and 1 (each within the scatter of the next).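

In this assay, within the data shown here, the change gives a number 1 percentage points lower from compound 1 to compound 3 (within the scatter), the first measured pair at this position. At the saturated chain carbon bound to a carbonyl carbon and an oxygen on a saturated carbon, 4-(tert-butyl)phenyl and naphthalen-2-yl, with one and 2 six-membered aromatic rings, are not told apart by this read-out. No available evidence bears on this result.

As far as these compounds go, what a plain phenyl, a pyridine ring or a carboxylic acid at this carbon would give remains open. So does the contribution of the methoxy group on the same carbon.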